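A few compounds are considered here, and "the series" means these few. Any claim that something is new, unique, unknown or untested is made for them only; others in the source may bear on it.

Compound 2, `CNC(=O)[C@@]12C[C@@H]1[C@@H](n1cnc3c(NC)nc(C#Cc4cccnc4)nc31)[C@H](O)[C@@H]2O`, was assayed in an assay on CHO cells for displacement of a labelled ligand from adenosine receptor A1 (Homo sapiens), read by scintillation counting, with a stated time of 60 min, tested at 10 uM (a higher number here means more inhibition at the concentration tested (going by the name of the read-out), a lower number less inhibition), where compound 2 gives 16%. For the measured compounds named here, its only measured neighbour, compound 1, `CNC(=O)[C@@]12C[C@@H]1[C@@H](n1cnc3c(NC)nc(C#Cc4cccc(C(F)(F)F)c4)nc31)[C@H](O)[C@@H]2O`, carries a 3-(trifluoromethyl)phenyl group in place of the pyridin-3-yl group; in this assay compound 1 gives 10%. The step of a number 6 percentage points higher from compound 1 to compound 2 (within the scatter) shows that exchanging the ring on the triple-bonded carbon left the result unchanged beyond the scatter, so compound 2 cannot be set apart from compound 1 on these numbers.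

The next compound, compound 3, `CNC(=O)[C@@]12C[C@@H]1[C@@H](n1cnc3c(NC)nc(C#Cc4ncccn4)nc31)[C@H](O)[C@@H]2O`, differs from compound 2 only by pyrimidin-2-yl in place of pyridin-3-yl on a triple-bonded carbon. Going by the values given here, the single step that bears on this change, a number 6 percentage points higher from compound 1 to compound 2 (within the scatter), was within the scatter, so another exchange of the aromatic ring on the triple-bonded carbon is expected to produce no step beyond the scatter, and the step of a number 2 percentage points lower from compound 2 to compound 3 (within the scatter) is estimated accordingly. For compound 3 in this assay the expected result is 14%, with a range from 2% to 28%.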

Compound 3, a percentage reported as inhibition, at one concentration (the size of the read-out at that concentration, not a potency): 25%
Compound 3: the middle estimate sits 11 percentage points below what was measured; measured number inside the range.
By their numbers in this assay, from the lowest: compounds 1, 2 and 3 (each within the scatter of the next, the first and the last beyond it).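

The change to pyrimidin-2-yl on the triple-bonded carbon gave a number 9 percentage points higher from compound 2 to compound 3 (within the scatter) in this assay and so still cannot be told apart from pyridin-3-yl. For the compounds shown here, the wider exchange, pyrimidin-2-yl in place of 3-(trifluoromethyl)phenyl, gave a number 15 percentage points higher from compound 1 to compound 3 (beyond the scatter) and is the first step at this position to pass the scatter, which shows that the ring held here can shift the result, if only modestly. Nothing available explains this step.

The compounds shown leave open whether an amine, a carboxylic acid or a longer chain on the triple-bonded carbon would read differently from these aromatic rings. They also leave open whether the modest step would hold at other concentrations, since each number is a reading at one concentration and not a potency.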